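The source may hold more compounds than are shown below. What is called first, only, known or untested is meant among the compounds shown, and "the series" means these compounds.

Going by the values given here, compound 2 `Cn1ccnc1[C@@H](CC(=O)O)c1ccc(OCc2cccc(-c3ccc(Cl)cc3Cl)c2)cc1` gives 30000 nM in an assay on CHO cells for agonist activity at Free fatty acid receptor 1 (Homo sapiens), read by luminescence, with a stated time of 20 s, in the presence of a further agent that is not named here (a higher number here means that more compound is needed for the effect, a lower number that less compound is needed), the lower of the two numbers so far, while compound 1 `CCc1ccccc1-c1cccc(COc2ccc([C@H](CC(=O)O)c3nccn3C)cc2)c1` gives 65000 nM. Among the compounds with values here, the one step between them, a 2.2-fold lower number from compound 1 to compound 2 (0.34 log units; beyond the scatter), came with 2,4-dichlorophenyl in place of 2-ethylphenyl. Compound 3 `Cc1cc(Cl)ccc1-c1cccc(COc2ccc([C@H](CC(=O)O)c3nccn3C)cc2)c1` differs from compound 2 by methyl in place of chloro on an aromatic carbon, ortho to a large group and meta to a chloro group, reading 2,4-dichlorophenyl to 4-chloro-2-methylphenyl. Within the data shown here, only that step bears on it, and it altered both positions at once, so the share of the group ortho to the large group is unresolved. Because compound 1 gives 65000 nM with an alkyl group there, the expected step is a 1.4-fold higher number from compound 2 to compound 3 (0.15 log units; within the scatter), likely within the scatter. Compound 3 is estimated at 42000 nM, range 20000 nM to 90000 nM.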

Compound 3, half-maximal effective concentration: 10000 nM
For compound 3 the middle estimate is 4.2-fold (0.62 log units) above the measured one; measured number outside the range, below it.
By their numbers in this assay, from the lowest: compound 3; then compound 2; then compound 1.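

In this assay, methyl in place of chloro, ortho to a large group, gives a 3.0-fold lower number from compound 2 to compound 3 (0.48 log units; beyond the scatter); this isolates the position that the step between compound 1 and compound 2 changed together with another. The change from 2-ethylphenyl to 4-chloro-2-methylphenyl gives a 6.5-fold lower number from compound 1 to compound 3 (0.81 log units; beyond the scatter), but it too alters two positions, so the shares of methyl and chloro cannot be separated. Nothing at hand explains the gain from methyl.

Open, from the compounds shown here alone, is how a hydrogen or a methoxy group would read at this position. Going by these compounds, the contribution of the remaining chloro group also stays open.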